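Swapping Fluoro for Chloro: What Compound 4 Should Show

This account rests on a few compounds, and the source may have more. Where it says the series, first, only, none or still open, it means among the compounds named here.

Three compounds have so far been measured in a functional assay on HeLa cells (Homo sapiens) for inhibition, read by CCK-8 assay, with a stated time of 72 h, tested at 2 uM; on this read-out lower numbers stand for less inhibition of growth and higher numbers for more inhibition of growth at the one concentration tested:

Compound 1, `Nc1ccccc1NC(=O)/C=C/c1ccc(CSc2ccc(Cl)cc2)cc1`, gives 1.94%.
Compound 2, `Nc1ccccc1NC(=O)/C=C/c1ccc(CSc2ccc(F)cc2)cc1`, gives 7.09%.
Compound 3, `Nc1ccccc1NC(=O)c1ccc(CSc2ccc(F)cc2)cc1`, gives 27.9%.

Compound 2 and compound 1 share one core and differ in a single spot: chloro in place of fluoro on an aromatic carbon. The step of a number 5.2 percentage points lower from compound 2 to compound 1 (within the scatter) shows that this swap hardly moves the read-out. Compound 3 is built on a different core; how that core differs from the core of compound 2 is not broken down here. What the numbers show is that compound 3 stands highest of the three, and its gap to compound 2 and to compound 1 lies beyond the scatter.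

Compound 4, `Nc1ccccc1NC(=O)c1ccc(CSc2ccc(Cl)cc2)cc1`, has not yet been measured. It arises from compound 3 by the same change: chloro in place of fluoro on an aromatic carbon. The place of the change reads the same in both pairs, so this is the same change, now made on the core of compound 3. Because the earlier instance of the swap gave the step of a number 5.2 percentage points lower from compound 2 to compound 1 (within the scatter), a step of similar size is expected here. The expected step is a number 4.9 percentage points lower from compound 3 to compound 4 (within the scatter). On that basis compound 4 is expected to give about 23% in this assay, with a likely range from 10% to 37%. This rests on one earlier instance of the swap, on another core, so the expectation carries real uncertainty.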

Compound 4, percent growth inhibition at one concentration: 19.2%
The estimate for compound 4 lay 3.8 percentage points above the measured number; the range from low to high includes it.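

In this assay, putting chloro in place of fluoro on the core of compound 3 gives a number 8.7 percentage points lower from compound 3 to compound 4 (within the scatter), so this instance of the swap, like the earlier one, does not clearly separate the two compounds. Set side by side, the swap reads alike on both cores, and the core makes no visible difference to its size: the same change on two cores in this assay, a number 5.2 percentage points lower (within the scatter) from compound 2 to compound 1 and a number 8.7 percentage points lower (within the scatter) from compound 3 to compound 4, 3.6 percentage points apart, within the scatter of two such steps. For the compounds shown here, this shows that, for this one pair of groups in this one read-out at a single concentration, the step seen on one core was a fair guide to the step on the other, but with only two cores it does not show that the swap would carry over to any further core, and since neither step lies beyond the scatter, it does not show that the swap itself has any real effect on growth inhibition.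

The compounds shown carry only fluoro or chloro at this place on the ring, so it remains open how a methyl, a methoxy, a nitrile, an amine or a carboxylic acid there would read in this assay. Also open, as far as these compounds go, is whether a longer chain in place of the link to this ring would leave the swap's small step unchanged.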